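This account rests on a few compounds, and the source may have more. Where it says the series, first, only, none or still open, it means among the compounds named here.

Measured so far:
- compound 1 `CC(C)C(NC(=O)c1ccccc1)C(=O)N1CCC(c2ccc(F)cc2)CC1`: 423 nM
- compound 2 `CC(C)[C@@H](NC(=O)CCc1ccc(F)cc1)C(=O)N1CCC(c2ccc(Cl)cc2)CC1`: 70 nM
- compound 3 `Cc1ccccc1C(=O)N[C@@H](C(=O)N1CCC(c2ccc(Cl)cc2)CC1)C(C)C`: 32 nM

The three compounds keep the same core and differ only in the group attached to one carbonyl carbon. In an assay on THP-1 cells for displacement of a labelled ligand from C-C chemokine receptor type 1 (Homo sapiens) (a lower number here means a stronger inhibitor, a higher number a weaker inhibitor), compound 3 gives the lowest number of the three. Its nearest neighbour is compound 2, and the step of a 2.2-fold lower number from compound 2 to compound 3 (0.34 log units; beyond the scatter) lies beyond the scatter. For the measured compounds named here, compound 1, with its 423 nM, lies furthest from compound 3 of the three, though no single-point step joins those two compounds.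

Compound 4 `CC(C)[C@@H](NC(=O)C1CCCC1)C(=O)N1CCC(c2ccc(Cl)cc2)CC1` has not been measured yet. It differs from compound 3 in one place: cyclopentyl in place of 2-methylphenyl on a carbonyl carbon. Going by the values given here, the only measured step touching that carbonyl carbon is a 2.2-fold lower number from compound 2 to compound 3 (0.34 log units; beyond the scatter), where an aromatic ring in place of a longer chain made the number modestly lower. Among the compounds with values here, no measured pair exchanges an aromatic ring for a saturated one, so that step gives only a loose guide. A saturated ring of similar size is expected to keep the number near that of compound 3, with perhaps a modest rise, so the step from compound 3 to compound 4 in this assay is estimated as a 1.9-fold higher number from compound 3 to compound 4 (0.27 log units; within the scatter). Compound 4 is therefore expected to give about 60 nM, within a range of 20 nM to 200 nM.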

Compound 4, half-maximal inhibitory concentration: 70 nM
Compound 4: middle estimate off by 1.2-fold (0.07 log units), on the low side; the range from low to high includes it.
By their numbers in this assay, from the lowest: compound 3; then compounds 2 and 4 (each within the scatter of the next); then compound 1.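

In this assay, for the compounds shown here, cyclopentyl in place of 2-methylphenyl on the carbonyl carbon gives a 2.2-fold higher number from compound 3 to compound 4 (0.34 log units; beyond the scatter), the first measured exchange of an aromatic ring for a non-aromatic ring at this position, and one that favours the aromatic group. Cyclopentyl in place of 2-(4-fluorophenyl)ethyl gives no change at the digits printed from compound 2 to compound 4 (within the scatter), so these two groups cannot be told apart here, and compound 2 goes against any simple rule that an aromatic ring at this position lowers the number, as it carries one too. Among these three groups, only 2-methylphenyl stands apart from the other two, and nothing available explains why this is so.

A plain phenyl group on the core of compound 3 would help separate the contribution of the methyl group from that of the aromatic ring itself. As far as these compounds go, it also remains open whether a cyclohexyl group, or a saturated ring carrying an amine, would give a number close to that of cyclopentyl or one closer to that of 2-methylphenyl.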